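The source may hold more compounds than are shown below. What is called first, only, known or untested is meant among the compounds shown, and "the series" means these compounds.

Measured in a functional assay on HL-60 cells (Homo sapiens) for antiproliferative activity, with a stated time of 72 h; a lower number here means a stronger inhibitor, a higher number a weaker inhibitor:
- compound 1 `OC[C@H]1O[C@@H](n2cnc3c(NCc4ccccc4Cl)ncnc32)[C@H](O)[C@@H]1O`: 1600 nM
- compound 2 `COc1cccc(CNc2ncnc3c2ncn3[C@@H]2O[C@H](CO)[C@@H](O)[C@H]2O)c1`: 4900 nM
- compound 3 `OC[C@H]1O[C@@H](n2cnc3c(NCc4ccc(Cl)cc4Cl)ncnc32)[C@H](O)[C@@H]1O`: 96300 nM

Compound 3 is the weakest of the three, with the highest number in this assay. Compound 4 `COc1ccc(CNc2ncnc3c2ncn3[C@@H]2O[C@H](CO)[C@@H](O)[C@H]2O)c(OC)c1` differs from it by 2,4-dimethoxyphenyl in place of 2,4-dichlorophenyl on a saturated chain carbon bound to a nitrogen on an aromatic ring. Two large measured steps bear on this change. Chloro in place of hydrogen gave a 60-fold higher number from compound 1 to compound 3 (1.78 log units; beyond the scatter), and 2,4-dichlorophenyl in place of 3-methoxyphenyl gave a 20-fold higher number from compound 2 to compound 3 (1.29 log units; beyond the scatter). Going by the values given here, both steps end at the 2,4-dichlorophenyl compound, while the only methoxy compound measured has a much lower number. Among the compounds with values here, no compound with two methoxy groups has been measured, so the recovery may be only partial. A large step towards a lower number is expected, estimated as a 9.6-fold lower number from compound 3 to compound 4 (0.98 log units; beyond the scatter). For compound 4 the estimated value is 10000 nM, with an expected range of 2500 nM to 50000 nM.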

Compound 4, half-maximal inhibitory concentration: 39000 nM
Compound 4: middle estimate off by 3.9-fold (0.59 log units), on the low side; low and high end bracket the measured number.
By their numbers in this assay, from the lowest: compound 1; then compound 2; then compound 4; then compound 3.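

In this assay the 2,4-dimethoxyphenyl group on this saturated chain carbon gives only a limited gain over 2,4-dichlorophenyl (a 2.5-fold lower number from compound 3 to compound 4 (0.39 log units; beyond the scatter)). A second methoxy group does not keep the level of the 3-methoxyphenyl compound (an 8.0-fold higher number from compound 2 to compound 4 (0.90 log units; beyond the scatter)). Both 2,4-disubstituted compounds now lie above the two compounds with a single substituent, and the 2-chlorophenyl compound stays well ahead (a 24-fold higher number from compound 1 to compound 4 (1.39 log units; beyond the scatter)).

On these data alone, whether an amine or a carboxylic acid on this phenyl ring would lower the number stays open. No measurement at hand accounts for these differences.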